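The source may report more compounds than this note shows. Statements on the series, on what has been measured and on what is new or still open speak of the compounds shown alone.

Compound 1 `CC1=CC[C@@H]([C@@](C)(O)CCCC(C)(C)NC=S)CC1`: in a functional assay on K562 cells (Homo sapiens) for cytotoxicity, read by sulforhodamine B assay (on this read-out higher numbers stand for weaker inhibition of growth and lower numbers for stronger inhibition of growth), compound 1 reaches only the limit of the assay, > 100000 nM.
Compound 2 `CC1=CC[C@@H]([C@@](C)(O)CCCC(C)(C)NC(=S)NN)CC1`: in this assay compound 2 gives 380 nM.
Compound 3 `CC1=CC[C@@H]([C@@](C)(O)CCCC(C)(C)NC(=S)N/N=C\c2ccc(C)cc2)CC1`: in this assay compound 3 gives 7950 nM.

Among the values that are actual numbers, compound 3 stands highest, meaning it inhibits growth least strongly. Its nearest neighbour is compound 2, and the step between them, a 21-fold higher number from compound 2 to compound 3 (1.32 log units; beyond the scatter), lies beyond the scatter. The other measured step, an at least 260-fold lower number from compound 1 to compound 2 (2.42 log units; beyond the scatter), also lies beyond the scatter.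

Compound 4 `CC1=CC[C@@H]([C@@](C)(O)CCCC(C)(C)NC(=S)N/N=C\c2ccc(O)cc2)CC1` differs from compound 3 in one place: hydroxy in place of methyl on an aromatic carbon. Neither measured step touches the aromatic ring itself: one changes what hangs on the thiocarbonyl carbon, the other adds the whole aromatic group. Among the measured compounds shown here, no measured step therefore shows how a swap of a single substituent on that ring affects this assay, and the two earlier steps give no guide to its direction. With nothing to suggest a shift, the expected step is a 1.0-fold higher number from compound 3 to compound 4 (0.00 log units; within the scatter), within the usual scatter. Compound 4 is accordingly expected to give about 8000 nM, with a likely range from 2500 nM to 25000 nM.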

Compound 4, concentration for total growth inhibition: 31100 nM
Estimate against measurement, compound 4: 3.9-fold (0.59 log units) below; measured number outside the range, above it.
By their numbers in this assay, from the lowest: compound 2; then compound 3; then compound 4. At a limit, above all of these: compound 1.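

The far end of the aromatic group turns out not to be a silent spot: in this assay, the change from 4-methylphenyl to 4-hydroxyphenyl gives a 3.9-fold higher number from compound 3 to compound 4 (0.59 log units; beyond the scatter) and so weakens growth inhibition by a modest but real amount. It also widens the cost of building on the free end of compound 2, since the hydroxy version gives an 82-fold higher number from compound 2 to compound 4 (1.91 log units; beyond the scatter) where the methyl version gives a 21-fold higher number from compound 2 to compound 3 (1.32 log units; beyond the scatter) in the same assay, so the choice of ring substituent decides part of how much is lost. Why hydroxy gives the higher number is something no measurement shown here can explain.

Going by these compounds, this single pair only ranks methyl and hydroxy on this one aromatic carbon, so it remains open how a plain hydrogen, a methoxy, an amine or a carboxylic acid would behave there. On these data alone, it also remains open whether any group on this ring could bring the number back towards that of compound 2, or whether the aromatic group as a whole sets the loss.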